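The source may report more compounds than this note shows. Statements on the series, on what has been measured and on what is new or still open speak of the compounds shown alone.

Of the compounds shown here, three sharing one core have been measured in a functional assay (muscle tissue) with Cavia porcellus as the target; a higher number here means that more compound is needed for the effect, a lower number that less compound is needed: compound 1 (`COC(=O)C1=C(C)N=C(C)/C(=C(\O)OC)C1c1ccccc1N`) gives 39800 nM, compound 2 (`COC(=O)C1=C(C)N=C(C)/C(=C(\O)OC)C1c1cccc(N(C)C)c1`) gives 891 nM, and compound 3 (`COC(=O)C1=C(C)N=C(C)/C(=C(\O)OC)C1c1ccccc1C(F)(F)F`) gives 1.51 nM. Compound 2 therefore holds the middle place of the three. Compound 4 (`COC(=O)C1=C(C)N=C(C)/C(=C(\O)OC)C1c1cccc(OC(C)=O)c1`) has acetoxy in place of dimethylamino on an aromatic carbon, meta to a large group: acetoxy in place of dimethylamino on an aromatic carbon. Going by the values given here, no measured step makes this swap. Among the compounds with values here, the only one available is a 26000-fold lower number from compound 1 to compound 3 (4.42 log units; beyond the scatter), with trifluoromethyl in place of amino, and it shows only that one swapped group can move the number very far. A much smaller drop is expected here, though its direction is uncertain. The expected move is a 4.5-fold lower number from compound 2 to compound 4 (0.65 log units; beyond the scatter). For compound 4 the estimate is 200 nM, with an expected range from 25 nM to 1500 nM.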

Compound 4, half-maximal effective concentration: 6030 nM
Estimate against measurement, compound 4: 30-fold (1.48 log units) below; measured number above the stated range.
By their numbers in this assay, from the lowest: compound 3; then compound 2; then compound 4; then compound 1.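

Acetoxy in place of dimethylamino on an aromatic carbon, meta to a large group, gives a 6.8-fold higher number from compound 2 to compound 4 (0.83 log units; beyond the scatter). Going by these compounds alone, this is the first step measured at this position, and it shows that here the larger acetoxy group, with its added hydrogen-bond acceptor, comes with a higher number, so more compound is needed. Nothing measured here accounts for this rise. From the compounds shown here alone, whether a methoxy or a hydroxyl group at this same place would give a lower number than either dimethylamino or acetoxy remains open.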